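Exchanging the heteroaryl amide on a shared acid core

The source may report more compounds than this note shows. Statements on the series, on what has been measured and on what is new or still open speak of the compounds shown alone.

Compound 1 `CC(C)[C@H](C(=O)Nc1cccnn1)c1ccc(Cl)cc1`: 2300 nM
Compound 2 `CC(C)[C@H](C(=O)Nc1cnns1)c1ccc(Cl)cc1`: 57000 nM

Of the compounds shown here, two sharing one core have been measured in a functional assay on CHO cells for agonist activity at Free fatty acid receptor 2 (Homo sapiens), read by cAMP accumulation; on this read-out higher numbers stand for weaker inhibition and lower numbers for stronger inhibition. Compound 1 gives 2300 nM, and compound 2 gives 57000 nM. Going by the values given here, compound 2 therefore stands at the highest of the two numbers, with compound 1 as its only neighbour; the one measured step, a 25-fold higher number from compound 1 to compound 2 (1.39 log units; beyond the scatter), shows how far the two heteroaryl amides lie apart.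

Compound 3 `CC(C)[C@H](C(=O)Nc1ncc(C#N)s1)c1ccc(Cl)cc1` is not yet measured. It differs from compound 2 in one place: 5-cyano-1,3-thiazol-2-yl in place of 1,2,3-thiadiazol-5-yl on an amide-type nitrogen. Among the compounds with values here, the sole step that bears on this exchange is the same one, a 25-fold higher number from compound 1 to compound 2 (1.39 log units; beyond the scatter), which shows that swapping one small heteroaryl ring on the amide nitrogen for another can move the number far beyond the scatter. Within the data shown here, no direct step from a 1,2,3-thiadiazol-5-yl to a 5-cyano-1,3-thiazol-2-yl is available, so the direction rests only on the fact that compound 2 is the weaker of the two measured amides and that another heteroaryl gave a much lower number. The expectation is that compound 3 moves back towards compound 1, a step of a 9.5-fold lower number from compound 2 to compound 3 (0.98 log units; beyond the scatter). Compound 3 is thus estimated at 6000 nM in this assay, within a range from 1000 nM to 35000 nM.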

Compound 3, half-maximal inhibitory concentration: 2000 nM
For compound 3 the middle estimate is 3.0-fold (0.48 log units) above the measured one, within the range that was stated.
By their numbers in this assay, from the lowest: compounds 3 and 1 (each within the scatter of the next); then compound 2.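

In this assay, the exchange of 1,2,3-thiadiazol-5-yl for 5-cyano-1,3-thiazol-2-yl on the amide-type nitrogen gives a 29-fold lower number from compound 2 to compound 3 (1.45 log units; beyond the scatter), so the high number of compound 2 does not hold for every five-membered aromatic ring with sulfur at this position. The two groups also have the same counted hydrogen-bond donors and acceptors, and that count therefore does not separate them on this read-out. The pyridazin-3-yl and 5-cyano-1,3-thiazol-2-yl groups show a 1.2-fold lower number from compound 1 to compound 3 (0.06 log units; within the scatter), which means that two quite different heteroaryl amides on the shared core can reach the same level here, while the 1,2,3-thiadiazol-5-yl group stays apart from both.

The compounds shown leave open what the nitrile contributes, and how a 1,3-thiazol-2-yl carrying a carboxylic acid, an amine or only hydrogen in its place would read. No measurement at hand bears on why these heteroaryl groups differ so much on this nitrogen.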